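The compounds below may be only part of what the source reports. "The series", "measured", "known", "first", "only" and "open" are said of these compounds alone.

In a functional assay on COLO 205 cells (Homo sapiens) for inhibition, read by sulforhodamine B assay, with a stated time of 48 h, tested at 50 uM (a higher number here means more inhibition of growth at the concentration tested, a lower number less inhibition of growth), compound 1 (`COc1ccc(/C=C/C(=O)/C=C/c2ccc(OCc3cn(CCCCOc4cc(=O)oc5ccccc45)nn3)c(OC)c2)cc1OC`) gives 53% and stands lowest of the two numbers at hand. Compound 2 (`COc1cc(/C=C/C(=O)/C=C/c2cc(OC)c(OC)c(OC)c2)ccc1OCc1cn(CCCOc2cc(=O)oc3ccccc23)nn1`) gives 74% and the gap between the two lies beyond the scatter. Among the measured compounds shown here, no two measured compounds differ in one place only, so no measured step guides the next change. Compound 3 (`COc1ccc(/C=C/C(=O)/C=C/c2ccc(OCc3cn(CCCCOc4cc(=O)oc5ccccc45)nn3)c(OC)c2)cc1`) remains unmeasured and departs from compound 1 by a single change (hydrogen in place of methoxy on an aromatic carbon): hydrogen in place of methoxy on an aromatic carbon, so that 3,4-dimethoxyphenyl becomes 4-methoxyphenyl. Without a measured step for this change, no shift beyond the scatter is expected in either direction. The estimated change is small, with a number 3 percentage points lower from compound 1 to compound 3 (within the scatter) expected to stay within the scatter. Compound 3 is expected at 50% with an estimated range from 33% to 67% around it.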

Compound 3, percent growth inhibition at one concentration: 49%
The estimate for compound 3 lay 1 percentage points above the measured number; measured number inside the range.
By their numbers in this assay, from the lowest: compounds 3 and 1 (each within the scatter of the next); then compound 2.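

Hydrogen in place of methoxy on this aromatic carbon gives the first single-place step readable in this assay, a step of a number 4 percentage points lower from compound 1 to compound 3 (within the scatter) and so the first direct reading at this position. Going from 3,4-dimethoxyphenyl to 4-methoxyphenyl therefore leaves growth inhibition at the tested concentration within the scatter, and this methoxy group is not needed for the level seen with compound 1. No measurement at hand gives a reason for this result.

Still open, going by these compounds, is whether a hydroxy group, an amine or a longer alkoxy chain such as butoxy on this same carbon would give a step beyond the scatter. Also open, on these data alone, is whether hydrogen in place of methoxy reads the same way on the aromatic ring of compound 2, which differs from compound 1 in more than one place.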